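The compounds below may be only part of what the source reports. "The series", "measured", "known", "first", "only" and "open" are said of these compounds alone.

Measured compounds:
compound 1 `O=C1C=CC2(C=C1)OCC(=O)N2c1nc(-c2ccc3ccccc3c2Br)nn1-c1ccccc1`, 50 nM
compound 2 `O=C1C=CC2(C=C1)OCC(=O)N2c1nc(-c2ccc3ccccc3c2)nn1-c1ccc2ccccc2c1`, 50 nM

Of the compounds shown here, two from this series have been tested in a functional assay on MDA-MB-231 cells (Homo sapiens) for antiproliferative activity, with a stated time of 5 days; a lower number here means a stronger inhibitor, a higher number a weaker inhibitor. Compound 1 gives 50 nM in this assay, and compound 2 gives 50 nM. Within the data shown here, at the digits reported, compound 1 stands level with compound 2, the only other measured compound, and the two values lie within the scatter of each other, so no order can be drawn between them.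

Compound 3 `O=C1C=CC2(C=C1)OCC(=O)N2c1nc(-c2ccc3c(c2)OCCO3)nn1-c1ccccc1` has not yet been measured. It differs from compound 1 in one place: 2,3-dihydro-1,4-benzodioxin-6-yl in place of 1-bromonaphthalen-2-yl on an aromatic carbon. Among the measured compounds shown here, no step between two measured compounds is known for this assay, so the size of this change can only be guessed. The two measured values show that a large two-ring aromatic group at this position is consistent with potency at the level of compound 1, and the group entering in compound 3 is smaller and carries two oxygen atoms. A modest loss is expected, a 2.0-fold higher number from compound 1 to compound 3 (0.30 log units; within the scatter), not far beyond the scatter. Compound 3 is therefore estimated to give 100 nM in this assay, with a range from 30 nM to 400 nM.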

Compound 3, half-maximal inhibitory concentration: 100 nM
Compound 3: middle estimate and measured number agree at the digits printed; the range from low to high includes it.
By their numbers in this assay, from the lowest: compounds 1, 2 and 3 (each within the scatter of the next).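

Among these compounds, the exchange of 1-bromonaphthalen-2-yl for 2,3-dihydro-1,4-benzodioxin-6-yl, on an aromatic carbon of the five-membered aromatic ring with 3 nitrogen, gives the first step that can be read at this position: in this assay it comes to a 2.0-fold higher number from compound 1 to compound 3 (0.30 log units; within the scatter). The position therefore does not depend, at this resolution, on a group made of two six-membered aromatic rings of carbon only: a group with one such ring, one six-membered non-aromatic ring with 2 hetero atoms and 2 hydrogen-bond acceptors stands within the scatter of compound 1. Nothing available explains this outcome, so it remains a description of the two structures and their numbers.

The step changes the ring system, the bromine and the oxygen atoms all at once, so the compounds shown leave open what each of these contributes on its own. They also leave open how far the position tolerates other kinds of group, such as a plain phenyl, a piperidine or a carboxylic acid in place of the bicyclic group.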